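Hydrazone Series on HEL Cells: Estimating the Fluorophenyl Analogue

The source may hold more compounds than are shown below. What is called first, only, known or untested is meant among the compounds shown, and "the series" means these compounds.

Measured compounds:
compound 1, `Cc1ccc(/C=N/NC(=O)COc2cccc3ccccc23)cc1`, 80.1 ug/mL
compound 2, `O=C(COc1cccc2ccccc12)N/N=C/c1ccc([N+](=O)[O-])cc1`, 14.2 ug/mL
compound 3, `O=C(COc1cccc2ccccc12)N/N=C/c1cccc(Br)c1`, 48.6 ug/mL

In an ADME assay on HEL cells (Homo sapiens) for cytotoxicity (a higher number here means that more compound is tolerated, a lower number that less compound is tolerated), compound 3 stands second highest of the three numbers; its nearest neighbour is compound 1, separated by a 1.6-fold lower number from compound 1 to compound 3 (0.22 log units; within the scatter), while compound 2 lies furthest from it. Compound 4, `O=C(COc1cccc2ccccc12)N/N=C/c1ccc(F)cc1`, differs from compound 3 by 4-fluorophenyl in place of 3-bromophenyl on a carbon with a double bond to nitrogen. Among the compounds with values here, no measured step swaps one halogenated phenyl for another. The step of a 1.6-fold lower number from compound 1 to compound 3 (0.22 log units; within the scatter) shows that exchanging one substituted phenyl for another stayed within the scatter, whereas a 5.6-fold lower number from compound 1 to compound 2 (0.75 log units; beyond the scatter) was a modest change beyond it, but that step involved a nitro group, absent here. The expectation for compound 4 is therefore a step of about a 1.1-fold higher number from compound 3 to compound 4 (0.05 log units; within the scatter), not beyond the scatter. Compound 4 is estimated at 55 ug/mL, within 25 ug/mL to 110 ug/mL.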

Compound 4, half-maximal cytotoxic concentration: 71.6 ug/mL
The estimate for compound 4 lay 1.3-fold (0.11 log units) below the measured number, and the stated range covers the measured number.
By their numbers in this assay, from the lowest: compound 2; then compounds 3, 4 and 1 (each within the scatter of the next).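

Within the data shown here, the first exchange of one halogenated phenyl for another, 4-fluorophenyl in place of 3-bromophenyl in this assay, stayed within the scatter (a 1.5-fold higher number from compound 3 to compound 4 (0.17 log units; within the scatter)). On the same aromatic carbon, fluoro in place of methyl also stayed within it (a 1.1-fold lower number from compound 1 to compound 4 (0.05 log units; within the scatter)), whereas fluoro in place of nitro went beyond it (a 5.0-fold higher number from compound 2 to compound 4 (0.70 log units; beyond the scatter)), so among these one-place steps at that carbon only those involving the nitro group leave the scatter. No evidence at hand accounts for these numbers.

The compounds shown leave open whether the effect of the halogen can be told apart from that of its place on the phenyl ring, and how in this assay an amine or a carboxylic acid on that ring would compare.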